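This account rests on a few compounds, and the source may have more. Where it says the series, first, only, none or still open, it means among the compounds named here.

Compound 1 `O=C(O)c1ccc(-c2cscn2)cc1O` carries a 1,3-thiazol-4-yl group on its core. In a functional assay on the whole organism for inhibition, with Rattus norvegicus as the target, read by paw edema (a lower number here means that less compound is needed, a higher number that more compound is needed for the effect), compound 1 gives 70 mg/kg. Among the measured compounds shown here, only one other compound yields a number in this assay: compound 2 `CC(=O)Oc1ccc(-n2cccc2)cc1C(=O)O`, which gives 42 mg/kg, a result that lies within the usual scatter of the value of compound 1, so the two cannot be told apart. Compound 3 `O=C(O)c1cc(-c2cc[nH]n2)ccc1O` gives no number in this assay but only a limit, > 250 mg/kg. That result is the limit of > 250 mg/kg in this assay, at which 1 of the 3 values shown sits.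

Compound 4 `O=C(O)c1ccc(-c2nccs2)cc1O` has not yet been measured. It differs from compound 1 in a single place: 1,3-thiazol-2-yl in place of 1,3-thiazol-4-yl on an aromatic carbon. The same atoms are present, joined differently, so the ring keeps its size and its kind of atoms and only the point at which it attaches to the core moves.

For the measured compounds named here, no pair of measured compounds shows what such a rearrangement of the ring does in this assay, so the direction of the step is uncertain. With the ring otherwise unchanged, a move of the attachment point is expected to shift the dose little. The step of no change at the digits printed from compound 1 to compound 4 (within the scatter) is therefore expected to stay within the scatter. Compound 4 is expected to give about 70 mg/kg in this assay, most likely between 30 mg/kg and 170 mg/kg.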

Compound 4, dose for half-maximal effect: 110 mg/kg
For compound 4 the middle estimate is 1.6-fold (0.20 log units) below the measured one; low and high end bracket the measured number.
By their numbers in this assay, from the lowest: compounds 2, 1 and 4 (each within the scatter of the next, the first and the last beyond it). At a limit, above all of these: compound 3.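

Moving the attachment point of the ring gives the first step in this assay that can be read between two compounds differing in one place: a 1.6-fold higher number from compound 1 to compound 4 (0.20 log units; within the scatter). On this aromatic carbon, para to a carboxy group and meta to a hydroxy group, the assay therefore cannot tell 1,3-thiazol-2-yl from 1,3-thiazol-4-yl, even though the ring attaches through a different atom. Compound 4 also gives a true number, so this step compares two numbers and does not rest on the value that is only a limit: the limit of > 250 mg/kg in this assay, at which 1 of the 4 values shown sits.

From the compounds shown here alone, this single pair says nothing about replacing the ring altogether, so it remains open whether a different group on the same carbon, such as an amine or a longer chain, would move the dose beyond the scatter. Going by these compounds, it also remains open what the hydroxy group contributes on the shared core, and whether a methoxy group in its place would leave the dose needed for the effect unchanged.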